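Swapping a Pyrrolidine Amide for a Hydroxyethoxy Side Chain

A few compounds are considered here, and "the series" means these few. Any claim that something is new, unique, unknown or untested is made for them only; others in the source may bear on it.

Compound 3 `CCCCCOC(=O)N1CCN(C(=O)[C@H](CCC(=O)O)NC(=O)c2cc(N3CCC(C(=O)N4CCCC4)CC3)nc(-c3ccccc3)n2)CC1` stands second highest of three numbers in an in vivo ADME assay on the whole organism (strain Sprague-Dawley) for pharmacokinetics, with Rattus norvegicus as the target (a lower number here means that more of the compound stays in the plasma, a higher number that more of the compound sits outside the plasma), where compound 3 gives 0.2 L/kg. Compound 2 `CCCCCOC(=O)N1CCN(C(=O)[C@H](CCC(=O)O)NC(=O)c2nc(-c3ccccc3)cc(N3CCC(COC)CC3)n2)CC1` gives 0.15 L/kg, within the scatter of compound 3, while compound 1 `CCCCCOC(=O)N1CCN(C(=O)[C@H](CCC(=O)O)NC(=O)c2cc(N3CCC(COC)CC3)nc(-c3ccccc3)n2)CC1` gives 1.1 L/kg. Within the data shown here, the one measured step between compounds differing in a single place is a 5.5-fold lower number from compound 1 to compound 3 (0.74 log units; beyond the scatter). Compound 4 `CCCCCOC(=O)N1CCN(C(=O)[C@H](CCC(=O)O)NC(=O)c2cc(N3CCC(OCCO)CC3)nc(-c3ccccc3)n2)CC1` differs from compound 3 by 2-hydroxyethoxy in place of (pyrrolidin-1-yl)carbonyl on a saturated ring carbon. Among the measured compounds shown here, no measured step exchanges a group at this saturated ring carbon for 2-hydroxyethoxy, so the relevant evidence is limited to a 5.5-fold lower number from compound 1 to compound 3 (0.74 log units; beyond the scatter) and to compound 2 sitting at 0.15 L/kg near compound 3. Compound 4 is therefore expected to show a 1.5-fold higher number from compound 3 to compound 4 (0.18 log units; within the scatter), landing at an estimated 0.3 L/kg within 0.12 L/kg to 0.7 L/kg.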

Compound 4, volume of distribution at steady state: 0.8 L/kg
Compound 4: middle estimate off by 2.7-fold (0.43 log units), on the low side, outside the stated range (above it).
By their numbers in this assay, from the lowest: compounds 2 and 3 (each within the scatter of the next); then compounds 4 and 1 (each within the scatter of the next).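

In this assay the change at this saturated ring carbon gives a 4.0-fold higher number from compound 3 to compound 4 (0.60 log units; beyond the scatter) and replacing methoxymethyl gives a 1.4-fold lower number from compound 1 to compound 4 (0.14 log units; within the scatter) so the two steps together separate the groups. Of the three groups compared at this place, 2-hydroxyethoxy and methoxymethyl cannot be told apart, and only (pyrrolidin-1-yl)carbonyl stands apart, on the low side. Nothing available accounts for this difference.

As far as these compounds go, it remains open whether an amine or a nitrile on this ring carbon would fall with (pyrrolidin-1-yl)carbonyl or with the other two groups, and whether 2-hydroxyethoxy would behave the same on the core of compound 2.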